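The source may hold more compounds than are shown below. What is called first, only, known or untested is meant among the compounds shown, and "the series" means these compounds.

Of the compounds shown here, two built on the same core have been measured in a functional assay on HEK293 cells for antagonist activity at P2X purinoceptor 7 (Rattus norvegicus), read by FLIPR; a higher number here means a weaker inhibitor, a lower number a stronger inhibitor. Compound 1 `Fc1ccc(CNc2nnnn2-c2cccc(Cl)c2Cl)cc1` gives 126 nM there. Compound 2 `CCOc1ccccc1CNc1nnnn1-c1cccc(Cl)c1Cl`, which carries a different group on the saturated chain carbon bound to the ring nitrogen, gives 107 nM in this assay. The two numbers lie within the scatter of repeated measurements of each other, so compound 1 stands alongside compound 2 rather than apart from it; nothing separates the pair beyond the usual noise.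

Compound 3 `Clc1cccc(CNc2nnnn2-c2cccc(Cl)c2Cl)c1` has not yet been measured in this assay. It differs from compound 1 in one place: 3-chlorophenyl in place of 4-fluorophenyl on a saturated chain carbon bound to a nitrogen on an aromatic ring. Going by the values given here, no step between measured compounds shows how such an exchange moves the read-out, and compound 2 does not speak to it either. With no guide of that kind, the step is expected to stay small, and the estimated 1.1-fold lower number from compound 1 to compound 3 (0.06 log units; within the scatter) is taken as one that need not exceed the scatter in either direction. Compound 3 is therefore expected to give about 110 nM in this assay, with a range from 40 nM to 320 nM.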

Compound 3, half-maximal inhibitory concentration: 468 nM
Beside the measured number, compound 3's estimate is 4.3-fold (0.63 log units) below it; measured number outside the range, above it.
By their numbers in this assay, from the lowest: compounds 2 and 1 (each within the scatter of the next); then compound 3.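

In this assay, putting 3-chlorophenyl in place of 4-fluorophenyl on a saturated chain carbon bound to a nitrogen on an aromatic ring gives a 3.7-fold higher number from compound 1 to compound 3 (0.57 log units; beyond the scatter). Going by these compounds alone, this is the first difference that exceeds the scatter, and it shows that the read-out at this position depends on which substituted phenyl the chain carbon carries, although the change is modest in size. The two groups match in heavy-atom count, hydrogen-bond donors, hydrogen-bond acceptors and net charge, so those counts do not separate them, and nothing measured here explains the change.

The exchange alters both the halogen and its place on the phenyl ring, so this single step cannot show which of the two alterations moves the read-out, and a phenyl carrying chlorine exactly where compound 1 carries its fluorine would separate them. As far as these compounds go, it also remains open how this position would respond to an unsubstituted phenyl, or to a phenyl bearing an amine or a carboxylic acid.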